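The source may report more compounds than this note shows. Statements on the series, on what has been measured and on what is new or still open speak of the compounds shown alone.

Measured so far:
- Compound 1, `O=C1N=C(NN2Cc3ccccc3N=C2c2ccccc2)S/C1=C/c1ccc(Br)cc1`: 2300 nM
- Compound 2, `COc1ccc(/C=C2/SC(NN3Cc4ccccc4N=C3c3ccccc3)=NC2=O)cc1OC`: 1000 nM

Within the data shown here, in a functional assay on MCF7 cells (Homo sapiens) for cytotoxicity, read by MTT assay, with a stated time of 4 h (on this read-out higher numbers stand for weaker inhibition and lower numbers for stronger inhibition), compound 2 has the lowest of the two numbers obtained so far, the only neighbour being compound 1 at 2300 nM. Among the measured compounds shown here, the one step that joins them, a 2.3-fold lower number from compound 1 to compound 2 (0.36 log units; beyond the scatter), is a modest change that nevertheless lies beyond the usual scatter of this kind of measurement.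

Compound 3, `O=C1N=C(NN2Cc3ccccc3N=C2c2ccccc2)S/C1=C/c1ccccc1`, has not yet been tested. It differs from compound 2 in one place: phenyl in place of 3,4-dimethoxyphenyl on a double-bonded chain carbon bound to a double-bonded ring carbon. The group at this position is the same position that was varied between compound 1 and compound 2, so that step is the only one that bears on the present change, and it shows that swapping the ring here can move the number by a modest but real amount in this assay.

Because the step of a 2.3-fold lower number from compound 1 to compound 2 (0.36 log units; beyond the scatter) went toward a lower number when the 3,4-dimethoxyphenyl came in, its removal is expected to move the number back up, and compound 3 is estimated at 2500 nM (range 900 nM to 7000 nM), a step of a 2.5-fold higher number from compound 2 to compound 3 (0.40 log units; beyond the scatter).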

Compound 3, half-maximal inhibitory concentration: 4050 nM
For compound 3 the middle estimate is 1.6-fold (0.21 log units) below the measured one, within the range that was stated.
By their numbers in this assay, from the lowest: compound 2; then compounds 1 and 3 (each within the scatter of the next).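

In this assay, with the plain phenyl ring now in place as a reference, a 4.1-fold higher number from compound 2 to compound 3 (0.61 log units; beyond the scatter). This puts compound 2 clearly lowest of the three, so the lower number goes with the 3,4-dimethoxyphenyl group rather than with any ring at this place on the molecule. Taking off the bromo group gives a different picture: a 1.8-fold higher number from compound 1 to compound 3 (0.25 log units; within the scatter), so in this assay, hydrogen and bromo on that aromatic carbon cannot be told apart, and the only change here that clearly moves the number is the one that brings in the 3,4-dimethoxyphenyl group. Nothing available explains this link between the group and the lower number.

Going by these compounds, it remains open whether both methoxy groups are needed or whether a single methoxy group on the phenyl ring would give the same low number. Also open, on these data alone, is how other groups on this ring, such as an amine, a carboxylic acid or a longer ether chain, would compare with the 3,4-dimethoxyphenyl group of compound 2.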